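Flipping One Double Bond from Z to E

This account rests on a few compounds, and the source may have more. Where it says the series, first, only, none or still open, it means among the compounds named here.

In a functional assay on the whole organism for cytotoxicity, with Homo sapiens as the target (on this read-out lower numbers stand for stronger inhibition of growth and higher numbers for weaker inhibition of growth), compound 1 (`CCCCCCn1c(=O)oc2ccc(NCc3cc(O)ccc3O)cc2c1=O`) gives 3900 nM and compound 2 (`Oc1ccc(O)c(CNc2ccc(O)c(/C=C\CCc3ccccc3)c2)c1`) gives 17100 nM as the higher, and so weaker, of the two numbers. The change to compound 3 (`Oc1ccc(O)c(CNc2ccc(O)c(/C=C/CCc3ccccc3)c2)c1`) is one of configuration alone (the two compounds have the same atoms and bonds and differ only in configuration as drawn: 1 of 1 stereo elements differ; a double bond is drawn Z in compound 2 and E in compound 3) with the same atoms and bonds. Within the data shown here, no measured pair shows what such a change does, so the estimated step (a 1.2-fold lower number from compound 2 to compound 3 (0.09 log units; within the scatter)) is expected to stay within the usual scatter. Compound 3 is expected at 14000 nM within an estimated range of 5500 nM to 35000 nM as its likely span.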

Compound 3, concentration for 50% growth inhibition: 5700 nM
For compound 3 the middle estimate is 2.5-fold (0.39 log units) above the measured one, within the range that was stated.
By their numbers in this assay, from the lowest: compounds 1 and 3 (each within the scatter of the next); then compound 2.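

In this assay, the geometry of the double bond alone makes a measurable difference, with a 3.0-fold lower number from compound 2 to compound 3 (0.48 log units; beyond the scatter). Among these compounds, no earlier pair of compounds separated configuration from every other change. This step can be assigned to the double bond's configuration, because nothing else in the structure changes: the fact that compounds 2 and 3 differ only in the configuration as drawn

These numbers do not tell why the E form gives the lower number. Going by these compounds, it also remains open whether the same gap between E and Z would appear with a longer chain, or with an amine on that chain.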